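A heteroaryl swap on the amide nitrogen of compound 3

This account rests on a few compounds, and the source may have more. Where it says the series, first, only, none or still open, it means among the compounds named here.

Measured compounds:
Compound 1, `Cc1cnc(NC(=O)COc2ccc(/C=C3\SC(=O)NC3=O)cc2)s1`, gives in a functional assay on KB cells (Homo sapiens) for cytotoxicity, read by sulforhodamine B assay, with a stated time of 48 h (on this read-out higher numbers stand for weaker inhibition of growth and lower numbers for stronger inhibition of growth), the limit < 100000 nM.
Compound 2, `O=C(COc1ccc(/C=C2\SC(=O)NC2=O)cc1)Nc1ncc([N+](=O)[O-])s1`, gives in this assay the limit < 100000 nM.
Compound 3, `O=C(COc1ccc(/C=C2\SC(=O)NC2=O)cc1)Nc1ccccn1`, gives in this assay the limit < 100000 nM.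

None of these three numbers is a real measurement: each is a limit of the assay, as the limit of < 100000 nM in this assay, at which 3 of the 3 values shown sit, records. Compound 3 therefore cannot be placed above or below its two neighbours, and the three steps among the measured compounds, a step that the two limits leave unreadable from compound 1 to compound 2, a step that the two limits leave unreadable from compound 1 to compound 3 and a step that the two limits leave unreadable from compound 2 to compound 3, have no readable size.

Compound 4, `Cc1cc(NC(=O)COc2ccc(/C=C3\SC(=O)NC3=O)cc2)no1`, differs from compound 3 by 5-methyl-1,2-oxazol-3-yl in place of pyridin-2-yl on an amide-type nitrogen. Among the measured compounds shown here, no measured step touches this change, and the steps that do exist are all unreadable, so there is no basis for expecting a shift in either direction beyond the scatter. The expected step from compound 3 to compound 4 in this assay is therefore a step that the limit leaves unreadable from compound 3 to compound 4. For compound 4 the estimate in this assay is 30000 nM, expected to fall between 3000 nM and 100000 nM, with a real chance that only a limit is reported again.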

Compound 4, concentration for 50% growth inhibition: < 100000 nM
Compound 4 was reported as a limit (the forecaster's own chance of this, stated with the estimate: 75%); the middle value does not contradict the limit.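

Compound 4 sits at the same assay limit as compound 1, compound 2 and compound 3, so no step between compound 4 and these three can be read: the limit of < 100000 nM in this assay, at which 4 of the 4 values shown sit.

The compounds shown leave open how strongly each inhibits growth in this assay, and whether the group on the amide-type nitrogen changes this at all.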